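The compounds below may be only part of what the source reports. "The series", "measured", "known", "first", "only" and "open" are said of these compounds alone.

Measured in an assay for inhibition of 15-hydroxyprostaglandin dehydrogenase [NAD(+)] (Homo sapiens), read by fluorescence, with a stated time of 15 min, in the presence of a further agent that is not named here; on this read-out higher numbers stand for weaker inhibition and lower numbers for stronger inhibition:
compound 1, `CCCC[S+]([O-])c1sc2nc(-c3nccs3)cc(-c3ccc(C(=O)OC)cc3)c2c1N`: 15.1 nM
compound 2, `CCC[S+]([O-])c1sc2nc(-c3cccs3)cc(C(=O)O)c2c1N`: 71 nM
compound 3, `CCCC[S+]([O-])c1sc2nc(-c3cccs3)ccc2c1N`: 1 nM

Compound 1 gives the second highest of the three numbers in this assay. Compound 2 reads higher than compound 1, beyond the scatter, and compound 3 reads lower, also beyond the scatter. No single-change step links any pair of these compounds, so these comparisons stand as bare values only.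

Compound 4, `CCCC[S+]([O-])c1sc2nc(-c3nccs3)cc(-c3ccc(C(=O)N(C)C)cc3)c2c1N`, is not yet measured in this assay. It differs from compound 1 in one place: dimethylamino in place of methoxy on a carbonyl carbon, that is, methoxycarbonyl to dimethylcarbamoyl. Within the data shown here, no measured pair shows this exchange, so nothing sets the size of the step. The step of a 1.3-fold higher number from compound 1 to compound 4 (0.12 log units; within the scatter) is expected to be small, within the scatter, with no clear direction. Compound 4 is expected to give 20 nM in this assay, in the range 6 nM to 60 nM.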

Compound 4, half-maximal inhibitory concentration: 5.9 nM
Estimate against measurement, compound 4: 3.4-fold (0.53 log units) above; measured number outside the range, below it.
By their numbers in this assay, from the lowest: compound 3; then compound 4; then compound 1; then compound 2.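

Among these compounds, on a carbonyl carbon bonded to an aromatic carbon, dimethylamino in place of methoxy gives a 2.6-fold lower number from compound 1 to compound 4 (0.41 log units; beyond the scatter), the first one-place step. The number at this position therefore responds to what sits on the carbonyl carbon, and methoxycarbonyl to dimethylcarbamoyl is a modest gain in inhibition, not a neutral exchange. Nothing available explains this step.

Open, from the compounds shown here alone, is how a carboxylic acid, a primary amide or a morpholine amide at this carbonyl carbon would read. Also open, going by these compounds, is whether a longer chain on the amide nitrogen would carry the step further.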